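Methoxy added to the benzyl group of compound 2

The source may report more compounds than this note shows. Statements on the series, on what has been measured and on what is new or still open speak of the compounds shown alone.

In a functional assay on MCF7 cells (Homo sapiens) for inhibition, read by MTT assay, with a stated time of 3 days (on this read-out higher numbers stand for weaker inhibition and lower numbers for stronger inhibition), compound 1 `C/C=C/COc1cc(/C=C\c2cc(OC)c(OC)c(OC)c2)ccc1OC` gives 5400 nM and compound 2 `COc1ccc(/C=C\c2cc(OC)c(OC)c(OC)c2)cc1OCc1ccccc1` gives 59000 nM, the higher of the two numbers. Compound 3 `COc1ccc(COc2cc(/C=C\c3cc(OC)c(OC)c(OC)c3)ccc2OC)cc1` differs from compound 2 in one place: methoxy in place of hydrogen on an aromatic carbon. Going by the values given here, the only measured step, an 11-fold higher number from compound 1 to compound 2 (1.04 log units; beyond the scatter), falls on the same side chain but is a different exchange, so it gives no direction here. No step beyond the scatter is therefore expected in this assay. Compound 3 is estimated at 40000 nM, with a range of 10000 nM to 120000 nM. The expected step is a 1.5-fold lower number from compound 2 to compound 3 (0.17 log units; within the scatter).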

Compound 3, half-maximal inhibitory concentration: 48000 nM
The estimate for compound 3 lay 1.2-fold (0.08 log units) below the measured number; low and high end bracket the measured number.
By their numbers in this assay, from the lowest: compound 1; then compounds 3 and 2 (each within the scatter of the next).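

In this assay the change from benzyl to 4-methoxybenzyl gives a 1.2-fold lower number from compound 2 to compound 3 (0.09 log units; within the scatter) and so no step beyond the scatter at this ring carbon. The gap to the prop-1-en-1-yl side chain remains with the added methoxy, as an 8.9-fold higher number from compound 1 to compound 3 (0.95 log units; beyond the scatter) shows. No measurement at hand explains these numbers. As far as these compounds go, whether an amine or a carboxylic acid at this ring carbon would give a step beyond the scatter stays open. Also open, from the compounds shown here alone, is how a longer chain in place of prop-1-en-1-yl would compare with compound 1.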